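Swapping the benzyl substituent on a triazole-linked chromone scaffold

This account rests on a few compounds, and the source may have more. Where it says the series, first, only, none or still open, it means among the compounds named here.

Measured so far:
- compound 1, `Cc1cccc(Cn2cc(COc3ccc4c(=O)ccoc4c3)nn2)c1`: 20300 nM
- compound 2, `O=c1ccoc2cc(OCc3cn(Cc4ccc(Cl)cc4Cl)nn3)ccc12`: 5260 nM
- compound 3, `O=c1ccoc2cc(OCc3cn(Cc4cccc([N+](=O)[O-])c4)nn3)ccc12`: 9450 nM

In a functional assay on A549 cells (Homo sapiens) for cytotoxicity, read by MTT assay, with a stated time of 48 h (a higher number here means a weaker inhibitor, a lower number a stronger inhibitor), compound 1 gives the highest number of the three. Its nearest neighbour is compound 3, where a 2.1-fold lower number from compound 1 to compound 3 (0.33 log units; beyond the scatter); its furthest is compound 2, where a 3.9-fold lower number from compound 1 to compound 2 (0.59 log units; beyond the scatter). Between compound 2 and compound 3 the gap is a 1.8-fold higher number from compound 2 to compound 3 (0.25 log units; within the scatter).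

Compound 4, `O=c1ccoc2cc(OCc3cn(Cc4ccccc4F)nn3)ccc12`, has not yet been measured in this assay. It differs from compound 1 in one place: 2-fluorophenyl in place of 3-methylphenyl on a saturated chain carbon bound to an aromatic nitrogen.

Among the compounds with values here, two measured steps bear on this change, since both replace the 3-methylphenyl of compound 1 with a differently substituted phenyl on the same saturated chain carbon bound to an aromatic nitrogen: a 3.9-fold lower number from compound 1 to compound 2 (0.59 log units; beyond the scatter) and a 2.1-fold lower number from compound 1 to compound 3 (0.33 log units; beyond the scatter). Both moved the number down by a modest amount. A single fluorine is a smaller alteration than either of those, so for compound 4 a modest lowering, possibly within the scatter, is expected: a 1.7-fold lower number from compound 1 to compound 4 (0.23 log units; within the scatter). The estimate for compound 4 is 12000 nM, expected to fall between 5000 nM and 28000 nM.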

Compound 4, half-maximal inhibitory concentration: 10800 nM
The estimate for compound 4 lay 1.1-fold (0.05 log units) above the measured number; measured number inside the range.
By their numbers in this assay, from the lowest: compounds 2, 3, 4 and 1 (each within the scatter of the next, the first and the last beyond it).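

In this assay, within the data shown here, 2-fluorobenzyl in place of 3-methylbenzyl gives a 1.9-fold lower number from compound 1 to compound 4 (0.27 log units; within the scatter), so this is the first replacement of the 3-methylphenyl at this position whose step stays inside the scatter. Compared with the other groups, the 2-fluorophenyl shows a 1.1-fold higher number from compound 3 to compound 4 (0.06 log units; within the scatter) and a 2.1-fold higher number from compound 2 to compound 4 (0.31 log units; beyond the scatter), which sets the 2,4-dichlorophenyl of compound 2 clear of both compound 1 and compound 4, though still not of compound 3. Nothing available explains these differences.

On these data alone, whether an amine or a carboxylic acid on the phenyl ring, or a longer chain in place of the benzyl link, would move the number further remains open. So does whether a single chlorine would match the two in compound 2.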